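The source may report more compounds than this note shows. Statements on the series, on what has been measured and on what is new or still open speak of the compounds shown alone.

In an assay on Sf9 cells for inhibition of Leucine-rich repeat serine/threonine-protein kinase 2 (Homo sapiens), read by TR-FRET, with stated times of 30 min and 2 h (a lower number here means a stronger inhibitor, a higher number a weaker inhibitor), the measured compounds stand as follows: compound 1 `O=C(Nc1ccnnc1)c1cc(N2C[C@H]3COC[C@H]3C2)ccc1OCc1ccccc1` gives 50.1 nM; compound 2 `CN1CCC(c2ccc(OCc3ccccc3)c(C(=O)Nc3ccnnc3)c2)CC1` gives 20 nM; compound 3 `O=C(Nc1cccc(Cl)c1)c1cc(C(F)(F)F)ccc1OCc1ccc(F)cc1` gives 12.6 nM.

Compound 2 holds the second highest of the three numbers. Among the compounds with values here, its nearest neighbour is compound 3, whose number sits within the scatter of it, so no order between those two can be read; its furthest is compound 1, from which the only single-place step in the set runs: a 2.5-fold lower number from compound 1 to compound 2 (0.40 log units; beyond the scatter), a modest gain on exchanging the bicyclic amine for 1-methylpiperidin-4-yl.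

Compound 4 `CN1CCN(c2ccc(OCc3ccccc3)c(C(=O)Nc3ccnnc3)c2)CC1` takes the change (4-methylpiperazin-1-yl in place of 1-methylpiperidin-4-yl on an aromatic carbon). The group leaving and the group entering are of the same size and both sit on the same aromatic carbon, meta to a (pyridazin-4-yl)carbamoyl group and para to a benzyloxy group. Within the data shown here, no measured step in this set swaps one six-membered non-aromatic ring for another of the same size, so the step from compound 1 to compound 2 bears only loosely, as a sign that changes at this position move the number modestly at most. A step in this assay of no more than the scatter is therefore expected, with the direction open: a 1.3-fold higher number from compound 2 to compound 4 (0.10 log units; within the scatter).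

Compound 4 is estimated at 25 nM, within 8 nM to 80 nM.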

Compound 4, half-maximal inhibitory concentration: 12.6 nM
Compound 4: middle estimate off by 2.0-fold (0.30 log units), on the high side; the range from low to high includes it.
By their numbers in this assay, from the lowest: compounds 3, 4 and 2 (each within the scatter of the next); then compound 1.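

In this assay, a 1.6-fold lower number from compound 2 to compound 4 (0.20 log units; within the scatter) shows that this aromatic carbon accepts a second ring nitrogen, with no readable shift in the number; the two six-membered rings cannot be ordered here. The wider step, a 4.0-fold lower number from compound 1 to compound 4 (0.60 log units; beyond the scatter), adds a second six-membered ring to compound 2 in standing clear of the fused bicyclic amine of compound 1, so among these three compounds, both monocyclic rings carry lower numbers than the bicyclic group, and none of the three goes against this. No measurement in hand accounts for either step, or for the lack of separation between the two six-membered rings.

Open at this position is whether the methyl on the ring nitrogen contributes to the number, which piperazin-1-yl without that methyl would test, and whether a ring nitrogen is needed at all, which morpholin-4-yl or tetrahydropyran-4-yl would test. Also open, on these data alone, is how an open-chain group such as dimethylamino or a carboxylic acid would stand on the same aromatic carbon.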